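A few compounds are considered here, and "the series" means these few. Any claim that something is new, unique, unknown or untested is made for them only; others in the source may bear on it.

Measured in a functional assay on MOLM-13 cells (Homo sapiens) for antiproliferative activity; on this read-out lower numbers stand for stronger inhibition and higher numbers for weaker inhibition:
Compound 1 `Cc1c(-c2ccc(-c3ccccc3F)cc2)nc2ccc(F)cc2c1C(F)F`: > 3000 nM, a limit.
Compound 2 `Cc1c(-c2ccc(-c3ccccc3F)cc2)nc2ccc(F)cc2c1C(O)C(F)(F)F`: 640 nM.
Compound 3 `Cc1c(-c2ccc(-c3ccccc3F)cc2)nc2ccc(F)cc2c1C(=O)C(F)(F)F`: > 3000 nM, a limit.

Compound 3 has no number, only a limit. The series meets (the limit of > 3000 nM in this assay, at which 2 of the 3 values shown sit), and compound 3 is one of those two compounds. The next structure, compound 4 `Cc1c(-c2ccc(-c3ccccc3F)cc2)nc2ccc(F)cc2c1-c1nnn[nH]1`, keeps the shared core and changes one group: 1H-tetrazol-5-yl in place of (trifluoromethyl)carbonyl on an aromatic carbon. In words, 1H-tetrazol-5-yl stands in place of (trifluoromethyl)carbonyl on an aromatic carbon, opposite the ring nitrogen.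

For the measured compounds named here, no measured step makes this exact exchange, but changes at the same carbon bear on it. They gave an at least 4.6-fold lower number from compound 1 to compound 2 (0.67 log units; beyond the scatter) and an at least 4.6-fold higher number from compound 2 to compound 3 (0.67 log units; beyond the scatter), both beyond the scatter, while the third comparison is a step that the two limits leave unreadable from compound 1 to compound 3. So this position can move the read-out by at least a modest amount, and compound 2 at 640 nM is the only member with a number. Like compound 2, compound 4 carries a hydrogen-bond donor at this carbon, which compound 3 lacks. A modest move towards a lower number is therefore expected, though compound 4 may well stay at the limit. The expected change is an at least 3.0-fold lower number from compound 3 to compound 4 (0.47 log units; beyond the scatter). For compound 4 the estimated value is 1000 nM, with an expected range of 200 nM to 5000 nM.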

Compound 4, half-maximal inhibitory concentration: > 3000 nM
Compound 4 was reported as a limit (the forecaster's own chance of this, stated with the estimate: 35%); at least 3.0-fold (0.47 log units) between middle value and limit.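

In this assay compound 4 gives > 3000 nM, which is a limit of the assay. For the compounds shown here, the one readable step is an at least 4.6-fold higher number from compound 2 to compound 4 (0.67 log units; beyond the scatter), so the 2,2,2-trifluoro-1-hydroxyethyl group remains the only group at this carbon, opposite the ring nitrogen, that gives a number, and 1H-tetrazol-5-yl, a second group with a hydrogen-bond donor, does not share that result. The steps from compound 1 and from compound 3 to compound 4 cannot be read, both ends being limits, and the series now gathers at a single ceiling: the limit of > 3000 nM in this assay, at which 3 of the 4 values shown sit.

As far as these compounds go, how far compound 1, compound 3 and compound 4 lie past that limit stays unknown, so no order among the three can be given. It also stays open whether a hydrogen-bond donor matters here at all, or only the 2,2,2-trifluoro-1-hydroxyethyl group as a whole: what a hydroxymethyl group, a carboxylic acid or an amine on this carbon would give in this assay cannot be told from the compounds shown.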